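From trifluoromethyl to acetyl on a shared core

A few compounds are considered here, and "the series" means these few. Any claim that something is new, unique, unknown or untested is made for them only; others in the source may bear on it.

Compound 1 `FC(F)(F)c1ccc(/C=C/[C@@H]2CCCCN2)cc1` at 0.99 ug/mL
Compound 2 `Cc1cccc(C)c1/C=C/[C@@H]1CCCCN1` at 6.27 ug/mL

In a functional assay on OVCAR-3 cells (Homo sapiens) for inhibition, read by MTT assay, with a stated time of 24 h (a lower number here means a stronger inhibitor, a higher number a weaker inhibitor), compound 1 stands lowest of the two measured compounds, and its gap to compound 2 lies beyond the scatter. Compound 3 `CC(=O)c1ccc(/C=C/[C@@H]2CCCCN2)cc1` has acetyl in place of trifluoromethyl on an aromatic carbon and awaits measurement. Going by the values given here, no measured pair shows this change, so the expectation is a judgement only. In this assay a moderate move towards a weaker inhibitor is expected, and the estimate is a 2.5-fold higher number from compound 1 to compound 3 (0.40 log units; beyond the scatter) for this change. For compound 3 the estimated value is 2.5 ug/mL with an expected range from 0.8 ug/mL to 8 ug/mL once measured.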

Compound 3, half-maximal inhibitory concentration: 2.18 ug/mL
The estimate for compound 3 lay 1.1-fold (0.06 log units) above the measured number; the measured number falls inside the stated range.
By their numbers in this assay, from the lowest: compound 1; then compound 3; then compound 2.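

In this assay, acetyl in place of trifluoromethyl on an aromatic carbon, para to a group of 8 heavy atoms, gives a 2.2-fold higher number from compound 1 to compound 3 (0.34 log units; beyond the scatter) on the shared core. Going by these compounds alone, this is the first measured change at a single place, and its size is modest though beyond the scatter. At this position, then, a group with a hydrogen-bond acceptor is compatible with inhibition, at a modest cost in the number.

From the compounds shown here alone, whether a nitrile, a carboxylic acid or an amine at this position would read closer to compound 1 or to compound 3 remains open. Nothing available here accounts for the step.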